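This account rests on a few compounds, and the source may have more. Where it says the series, first, only, none or still open, it means among the compounds named here.

Compound 1 `O=C(/C=C/c1ccc(O)c(O)c1)N1CCN(c2ccccc2Cl)CC1`: 1.82 ug/mL
Compound 2 `COc1ccccc1N1CCN(C(=O)/C=C/c2ccc(O)c(O)c2)CC1`: 1.23 ug/mL
Compound 3 `O=C(/C=C/c1ccc(O)c(O)c1)N1CCN(c2ccc([N+](=O)[O-])cc2)CC1`: 1.79 ug/mL

These three compounds share one core and differ only in the aromatic group on the ring nitrogen. In a functional assay on B16-F10 cells (Mus musculus) for antiproliferative activity, read by MTT assay, with a stated time of 48 h (a lower number here means a stronger inhibitor, a higher number a weaker inhibitor), compound 1 has the highest of the three numbers, but both gaps are small: a 1.0-fold lower number from compound 1 to compound 3 (0.01 log units; within the scatter) and a 1.5-fold lower number from compound 1 to compound 2 (0.17 log units; within the scatter), so the three compounds cannot be told apart here.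

Compound 4 `O=C(/C=C/c1ccc(O)c(O)c1)N1CCN(c2ccccn2)CC1` is the next member. Relative to compound 1 the change is pyridin-2-yl in place of 2-chlorophenyl on an amine nitrogen in a ring. For the measured compounds named here, the steps that bear on this are the two swaps of the whole aromatic group on the ring nitrogen, a 1.0-fold lower number from compound 1 to compound 3 (0.01 log units; within the scatter) and a 1.5-fold higher number from compound 2 to compound 3 (0.16 log units; within the scatter), both within the scatter, and the swap of one ring substituent, a 1.5-fold lower number from compound 1 to compound 2 (0.17 log units; within the scatter), also within the scatter. Going by the values given here, nothing measured so far shows that the group on the ring nitrogen moves the number beyond the scatter, and no pyridine ring has yet been tested, so an expectation can only be cautious.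

Compound 4 is therefore expected to give a step of a 1.0-fold lower number from compound 1 to compound 4 (0.00 log units; within the scatter), that is, no change beyond the scatter. The expected value for compound 4 is 1.8 ug/mL, with a range from 0.9 ug/mL to 3.6 ug/mL.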

Compound 4, half-maximal inhibitory concentration: 3.01 ug/mL
The estimate for compound 4 lay 1.7-fold (0.22 log units) below the measured number; the measured number falls inside the stated range.
By their numbers in this assay, from the lowest: compounds 2, 3, 1 and 4 (each within the scatter of the next, the first and the last beyond it).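

In this assay, for the compounds shown here, the pyridin-2-yl group gives the only step that passes the scatter (a 2.4-fold higher number from compound 2 to compound 4 (0.39 log units; beyond the scatter)), which shows that the aromatic group on the ring nitrogen can move the number, though only modestly. That separation holds against the 2-methoxyphenyl group alone, as the other two steps stay within the scatter (a 1.7-fold higher number from compound 1 to compound 4 (0.22 log units; within the scatter); a 1.7-fold higher number from compound 3 to compound 4 (0.23 log units; within the scatter)), so compound 1 and compound 3 cannot be told apart from compound 4. Going by these compounds alone, this is also the first change here that puts a hetero atom in the aromatic ring and adds a hydrogen-bond acceptor, but no measurement at hand explains the step, so the change can be recorded and not interpreted.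

The compounds shown leave open whether the ring nitrogen of the pyridin-2-yl group matters in itself, since an unsubstituted phenyl ring, the closest carbon-only partner, is not among them. A pyrimidin-2-yl ring or a benzyl group on the same ring nitrogen would also show whether the number keeps rising or whether this modest gap is as far as the position goes.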